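Replacing chloro with trifluoromethyl in compound 1

The compounds below may be only part of what the source reports. "The series", "measured", "known", "first", "only" and "open" are said of these compounds alone.

Going by the values given here, compound 1 `O=C(Nc1nc(-c2ccccc2)nc2c1nnn2Cc1ccccc1)c1ccc(Cl)cc1` sits second highest of the three numbers so far. In an assay (strain Wistar) for displacement of a labelled ligand from adenosine receptor A1 (Rattus norvegicus), read by scintillation counting (a lower number here means a stronger inhibitor, a higher number a weaker inhibitor), compound 1 gives 108 nM. Compound 2 `O=C(Nc1nc(-c2ccccc2)nc2c1nnn2Cc1ccccc1)c1cccc(F)c1` gives 22 nM, a change of a 4.9-fold lower number from compound 1 to compound 2 (0.69 log units; beyond the scatter), while compound 3 `O=C(Nc1nc(-c2ccccc2)nc2c1nnn2Cc1ccccc1)c1ccccc1C(F)(F)F` gives 550 nM, a change of a 5.1-fold higher number from compound 1 to compound 3 (0.71 log units; beyond the scatter). Compound 4 `O=C(Nc1nc(-c2ccccc2)nc2c1nnn2Cc1ccccc1)c1ccc(C(F)(F)F)cc1` differs from compound 1 by trifluoromethyl in place of chloro on an aromatic carbon.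

Among the compounds with values here, no measured step isolates this exact change. The step from compound 1 to compound 3 also brings in trifluoromethyl but moves it to another carbon of the ring, and it weakened binding by a 5.1-fold higher number from compound 1 to compound 3 (0.71 log units; beyond the scatter). The step from compound 1 to compound 2 shifted the halogen and shrank it, and it strengthened binding by a 4.9-fold lower number from compound 1 to compound 2 (0.69 log units; beyond the scatter). Both steps change two things at once, so they give only a loose guide. A modest weakening or a step within the scatter is expected, amounting to a 1.9-fold higher number from compound 1 to compound 4 (0.27 log units; within the scatter). Compound 4 is therefore estimated at 200 nM, with a range from 60 nM to 650 nM.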

Compound 4, inhibition constant: 123 nM
Compound 4: the middle estimate sits 1.6-fold (0.21 log units) above what was measured; the range from low to high includes it.
By their numbers in this assay, from the lowest: compound 2; then compounds 1 and 4 (each within the scatter of the next); then compound 3.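

At the ring carbon para to a large group, chloro and trifluoromethyl cannot be told apart in this assay, as the exchange gives a 1.1-fold higher number from compound 1 to compound 4 (0.06 log units; within the scatter) even though the entering group holds more heavy atoms. With trifluoromethyl on the ring in both compounds, its place alone now shows an effect, as going from 2-(trifluoromethyl)phenyl to 4-(trifluoromethyl)phenyl gives a 4.5-fold lower number from compound 3 to compound 4 (0.65 log units; beyond the scatter), yet the 3-fluorophenyl group still binds more strongly, with a 5.6-fold higher number from compound 2 to compound 4 (0.75 log units; beyond the scatter) on going to 4-(trifluoromethyl)phenyl. No measurement here explains these differences.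

Still open, going by these compounds, is whether the 3-fluorophenyl advantage comes from the place of the group or from fluoro itself. The compounds shown also do not tell how this para carbon would respond to an amine or a carboxylic acid.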